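A few compounds are considered here, and "the series" means these few. Any claim that something is new, unique, unknown or untested is made for them only; others in the source may bear on it.

Of the compounds shown here, three share one core and have been measured in a functional assay on HCT-116 cells (Homo sapiens) for inhibition, read by sulforhodamine B assay, with a stated time of 72 h; on this read-out higher numbers stand for weaker inhibition and lower numbers for stronger inhibition. Compound 3 `COc1ccc(C(=O)/C=C/c2cn(-c3ccccc3)nc2-c2cccnc2)c(OC)c1OC` gives 1100 nM, the lowest number of the three, yet compound 2 `O=C(/C=C/c1cn(-c2ccccc2)nc1-c1cccnc1)c1ccccn1` with 2100 nM and compound 1 `COc1ccc(C(=O)/C=C/c2cn(-c3ccccc3)nc2-c2ccsc2)c(OC)c1` with 2200 nM both sit within the usual scatter of it, so the three cannot be told apart on these numbers.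

Compound 4 `COc1ccc(C(=O)/C=C/c2cn(-c3ccccc3)nc2-c2cccnc2)c(OC)c1` has not been measured in this assay. It differs from compound 3 in one place: hydrogen in place of methoxy on an aromatic carbon. Going by the values given here, no pair of measured compounds shows this same change, so its size is not known from this set. Since compound 1 also carries two methoxy groups and gives 2200 nM, while compound 3 with three gives 1100 nM, a modest move toward weaker inhibition is expected, though it may not exceed the scatter.

For compound 4 in this assay the expected value is 2000 nM, within a range of 900 nM to 4500 nM. The step this estimate implies is a 1.8-fold higher number from compound 3 to compound 4 (0.26 log units; within the scatter), expected to be small.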

Compound 4, half-maximal inhibitory concentration: 1300 nM
Beside the measured number, compound 4's estimate is 1.5-fold (0.19 log units) above it; the measured number falls inside the stated range.
By their numbers in this assay, from the lowest: compounds 3, 4, 2 and 1 (each within the scatter of the next).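

In this assay, replacing the methoxy group that sits ortho to two methoxy groups with hydrogen gives a 1.2-fold higher number from compound 3 to compound 4 (0.07 log units; within the scatter) and so stays within the scatter, which means that on these numbers this aromatic carbon can carry either group without a readable loss. The two other new comparisons are also within the scatter: 2,4-dimethoxyphenyl in place of pyridin-2-yl on a carbonyl carbon gives a 1.6-fold lower number from compound 2 to compound 4 (0.21 log units; within the scatter) while pyridin-3-yl in place of thiophen-3-yl on an aromatic carbon gives a 1.7-fold lower number from compound 1 to compound 4 (0.23 log units; within the scatter) and neither change separates the compounds. No independent evidence bears on these results.

On these data alone, only hydrogen and methoxy appear at this position, so what an amine, a fluorine atom or a longer chain such as ethoxy would do there remains open. As far as these compounds go, whether any change to this shared core can move the number beyond the scatter also remains unknown.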